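Shrinking the Hydroxylated Ring on a Nitrile-Bearing Core

The compounds below may be only part of what the source reports. "The series", "measured", "known", "first", "only" and "open" are said of these compounds alone.

Of the compounds shown here, three have been measured in an assay on isolated protein for inhibition of protein kinase C theta type (Homo sapiens), read by TR-FRET, with a stated time of 2 h; on this read-out lower numbers stand for stronger inhibition and higher numbers for weaker inhibition. Compound 1 `N#Cc1cnc(NCc2cnccc2C(F)(F)F)cc1N[C@H]1C[C@H](O)C1` gives 900 nM. Compound 2 `CO[C@H]1CC[C@@H](CNc2cc(NCc3cnccc3C(F)(F)F)ncc2C#N)CC1` carries a (4-methoxycyclohexyl)methyl group where compound 1 has 3-hydroxycyclobutyl. In this assay, for the measured compounds named here, compound 2 gives 70 nM, and the step of a 13-fold lower number from compound 1 to compound 2 (1.11 log units; beyond the scatter) is the only single-point comparison within the measured set. Compound 3 `CC1(C)C[C@H](Nc2nc(NCc3cnccc3C(F)(F)F)ncc2C#N)CC[C@@H]1O` gives 6 nM, the lowest of the three numbers; its separation from compound 2 and from compound 1 is in each case well beyond the scatter.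

Compound 4 `CC1(C)[C@H](O)C[C@@H]1Nc1nc(NCc2cnccc2C(F)(F)F)ncc1C#N` differs from compound 3 in one place: 3-hydroxy-2,2-dimethylcyclobutyl in place of 4-hydroxy-3,3-dimethylcyclohexyl on a nitrogen on an aromatic ring. Going by the values given here, no measured step maps exactly onto this change, as the core of compound 1 is not that of compound 3. Still, the step from compound 1 to compound 2 bears on it: there a four-membered hydroxylated ring gave way to a six-membered ring and the number fell sharply. The change from compound 3 to compound 4 runs the other way, from a six-membered to a four-membered ring, so a move toward higher numbers is expected, though the dimethyl substitution retained in compound 4 leaves the size uncertain. Compound 4 is expected to show a 6.7-fold higher number from compound 3 to compound 4 (0.82 log units; beyond the scatter) in this assay, with an estimated 40 nM (range 10 nM to 200 nM).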

Compound 4, half-maximal inhibitory concentration: 300 nM
The estimate for compound 4 lay 7.5-fold (0.88 log units) below the measured number; the measured number lies above the stated range.
By their numbers in this assay, from the lowest: compound 3; then compound 2; then compound 4; then compound 1.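

On the shared core of compound 3 and compound 4, the change of 4-hydroxy-3,3-dimethylcyclohexyl to 3-hydroxy-2,2-dimethylcyclobutyl on a nitrogen on an aromatic ring gives a 50-fold higher number from compound 3 to compound 4 (1.70 log units; beyond the scatter) in this assay, so this position is highly sensitive to the ring it carries. Unlike the earlier step of a 13-fold lower number from compound 1 to compound 2 (1.11 log units; beyond the scatter), which also swapped hydroxy for a methoxy-bearing group on a different core, this step keeps one hydroxy group and two methyl groups on both rings, and those retained groups do not hold the number near that of compound 3. In both listed steps the four-membered ring carries the higher number, though nothing measured here explains the size of the new step.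

The compounds shown do not separate the drop in ring size from the shift of the hydroxy and the two methyl groups around the ring, and they do not show whether a hydroxy-dimethylcyclopentyl group would fall nearer compound 3 or compound 4. As far as these compounds go, it also remains open whether an amine could stand in place of the hydroxy on the six-membered ring of compound 3 with the number kept low.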